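The source may hold more compounds than are shown below. What is called first, only, known or untested is meant among the compounds shown, and "the series" means these compounds.

Measured so far in an ADME assay on MDCK cells (Canis lupus familiaris) for cytotoxicity, read by MTT assay, with a stated time of 2 days; a higher number here means that more compound is tolerated, a lower number that less compound is tolerated:
compound 1 `O=C(NCCCCc1ccc(-c2cccs2)s1)c1cc(F)cc(C(F)(F)F)c1`, 27400 nM
compound 2 `O=C(NCCCCc1cccs1)c1cc(F)cc(C(F)(F)F)c1`, 43500 nM
compound 3 `BrCCCCc1ccc(-c2ccc(-c3ccc(-c4cccs4)s3)s2)s1`, "not determined" (no result reported)

The difference between the core of compound 1 and the core of compound 3 is not broken down here. Compound 2 carries hydrogen in place of thiophen-2-yl on an aromatic carbon relative to compound 1; in this assay this gives a 1.6-fold higher number from compound 1 to compound 2 (0.20 log units; within the scatter). Compound 4 `BrCCCCc1ccc(-c2ccc(-c3cccs3)s2)s1` carries hydrogen in place of thiophen-2-yl on an aromatic carbon relative to compound 3, the same change as from compound 1 to compound 2. Compound 3 has no number in this assay, so there is no anchor to which the earlier step could be applied. Because a 1.6-fold higher number from compound 1 to compound 2 (0.20 log units; within the scatter) lies within the scatter, the step from compound 3 to compound 4 is expected to be small. Among the measured compounds shown here, with the values of compound 1 and compound 2 as the only guide, compound 4 is expected to give about 30000 nM in this assay, estimated to fall between 6000 nM and 100000 nM.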

Compound 4, half-maximal cytotoxic concentration: 23800 nM
For compound 4 the middle estimate is 1.3-fold (0.10 log units) above the measured one; the range from low to high includes it.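

Among the compounds shown here, with no number for compound 3 in this assay, no step from compound 3 to compound 4 can be read. Left open is whether hydrogen in place of thiophen-2-yl on the core of compound 3 matches a 1.6-fold higher number from compound 1 to compound 2 (0.20 log units; within the scatter) and nothing shown accounts for the value of compound 4.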